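The compounds below may be only part of what the source reports. "The series", "measured", "known", "first", "only" and "open" are said of these compounds alone.

Compound 1 `O=C(Nc1cc(C(F)(F)F)cc(C(F)(F)F)c1)c1cnc(Cl)nc1`: 300 nM
Compound 2 `Cc1cc(C(=O)Nc2cc(C(F)(F)F)cc(C(F)(F)F)c2)nc(Cl)n1`: > 10000 nM

In an assay on Jurkat cells for activation of nuclear factor NF-kappa-B complex (Homo sapiens) (on this read-out higher numbers stand for weaker inhibition and lower numbers for stronger inhibition), compound 1 gives 300 nM. Compound 2 sits at the limit of > 10000 nM in this assay, at which 1 of the 2 values shown sits, which is a limit of the measurement and not a number. Among the measured compounds shown here, the single measured step, an at least 33-fold higher number from compound 1 to compound 2 (1.52 log units; beyond the scatter), is large. Compound 3 `O=C(Nc1cc(C(F)(F)F)cc(C(F)(F)F)c1)c1ccc(Cl)nn1` carries 6-chloropyridazin-3-yl in place of 2-chloro-6-methylpyrimidin-4-yl on a carbonyl carbon. For the measured compounds named here, no measured step covers a ring of this kind, so that large step gives only rough guidance here, and a weak result is again expected. The expected step is an at least 1.2-fold lower number from compound 2 to compound 3 (0.09 log units; that floor lies within the scatter). Compound 3 is estimated at 8000 nM, with a range from 1500 nM to 30000 nM.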

Compound 3, half-maximal inhibitory concentration: 1700 nM
Estimate against measurement, compound 3: 4.7-fold (0.67 log units) above; low and high end bracket the measured number.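

The ring on the carbonyl carbon can change without activity falling out of the measurable range, as 6-chloropyridazin-3-yl gives an at least 5.8-fold lower number from compound 2 to compound 3 (0.76 log units; beyond the scatter). The reading for compound 2 is only a limit, so this step is a minimum: the limit of > 10000 nM in this assay, at which 1 of the 3 values shown sits. Even so, the ring is not freely interchangeable, since 2-chloropyrimidin-5-yl remains the better of the two measured rings, with a 5.7-fold higher number from compound 1 to compound 3 (0.75 log units; beyond the scatter).

Going by these compounds, all three rings carry chlorine, so it remains open whether an amine or a methoxy group could replace it. The methyl group of compound 2 also cannot be separated from the change in ring.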